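Extending the Aryloxy Tail: What Compound 3 Might Give

The source may hold more compounds than are shown below. What is called first, only, known or untested is meant among the compounds shown, and "the series" means these compounds.

Measured compounds:
compound 1 `CC(C)[C@H](NC(=O)COc1cccc2ccccc12)C(=O)N[C@@H](CC(=O)O)C(=O)COc1ccccc1`: 14000 nM in a functional assay on Jurkat cells (Homo sapiens); a higher number here means a weaker inhibitor, a lower number a stronger inhibitor
compound 2 `CC(C)[C@H](NC(=O)COc1cccc2ccccc12)C(=O)N[C@@H](CC(=O)O)C(=O)COc1cccc2ccccc12`: its result in this assay is a limit, > 100000 nM

Compound 1 holds the only numerical result in this assay; the other entry is a limit. The limit for compound 2 rests at the limit of > 100000 nM in this assay, at which 1 of the 2 values shown sits. For the measured compounds named here, the single measured step, an at least 7.1-fold higher number from compound 1 to compound 2 (0.85 log units; beyond the scatter), changed the same oxygen-bearing aromatic group on a saturated carbon that is altered again in compound 3 `CC(C)[C@H](NC(=O)COc1cccc2ccccc12)C(=O)N[C@@H](CC(=O)O)C(=O)COc1ccc(Oc2ccc(C(F)(F)F)cc2)cc1`, where (4-(trifluoromethyl)phenoxy in place of hydrogen on an aromatic carbon). That step lay beyond the scatter and weakened inhibition, so it bears loosely on the new change, though a different group enters here. A modest weakening is therefore expected for compound 3, with a fair chance that only a limit is returned. Compound 3 is estimated at 35000 nM, within 9000 nM to 140000 nM, which amounts to an expected 2.5-fold higher number from compound 1 to compound 3 (0.40 log units; beyond the scatter).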

Compound 3, half-maximal inhibitory concentration: 9300 nM
Estimate against measurement, compound 3: 3.8-fold (0.58 log units) above; measured number inside the range.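

Placing 4-(trifluoromethyl)phenoxy on the aromatic carbon gives a 1.5-fold lower number from compound 1 to compound 3 (0.18 log units; within the scatter), so the two compounds read alike in this assay. For the compounds shown here, this position therefore accepts a substantial added group with an extra aromatic ring and no change beyond the scatter, something the earlier step, an at least 7.1-fold higher number from compound 1 to compound 2 (0.85 log units; beyond the scatter), gave no sign of, since that was the only change seen here and it went against inhibition. Compound 2 remains a limit, not a number: the limit of > 100000 nM in this assay, at which 1 of the 3 values shown sits.

What the compounds shown leave open is which part of the new group matters, for instance whether plain phenoxy without the trifluoromethyl would read the same. Also open, on these data alone, is whether a carboxylic acid or an amine on the same aromatic carbon would be accepted as well.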